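Chain extension on a squaramide-free core toward the hexadecyl analogue

A few compounds are considered here, and "the series" means these few. Any claim that something is new, unique, unknown or untested is made for them only; others in the source may bear on it.

Compound 3 `CCCCCCNc1c(N(C)CCCN(C)C)c(=O)c1=O` gives 900000 nM in an ADME assay on Vero cells (Chlorocebus sabaeus) for cytotoxicity, read by resazurin assay, with a stated time of 72 h (on this read-out higher numbers stand for weaker inhibition and lower numbers for stronger inhibition), the second highest of the three numbers recorded. Its nearest neighbour is compound 1 `CN(C)CCCN(C)c1c(N)c(=O)c1=O` with 1070000 nM, and the furthest is compound 2 `CCCCNc1c(N(C)CCCN(C)C)c(=O)c1=O` with 439000 nM. The unmeasured compound 4 `CCCCCCCCCCCCCCCCNc1c(N(C)CCCN(C)C)c(=O)c1=O` differs from compound 3 by decyl in place of hydrogen on a saturated chain carbon, six bonds along the chain from a nitrogen on an aromatic ring. For the measured compounds named here, the one step that bears on this change is the extension of the same chain, a 2.1-fold higher number from compound 2 to compound 3 (0.31 log units; beyond the scatter); the two steps on the ring nitrogen, a 2.4-fold lower number from compound 1 to compound 2 (0.39 log units; beyond the scatter) and a 1.2-fold lower number from compound 1 to compound 3 (0.08 log units; within the scatter), touch a different place. A far longer chain is now added, so the expected step for compound 4 is a 1.8-fold lower number from compound 3 to compound 4 (0.26 log units; within the scatter), with wide uncertainty. Compound 4 is therefore estimated at 500000 nM, within a range of 100000 nM to 2000000 nM.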

Compound 4, half-maximal inhibitory concentration: 679000 nM
The estimate for compound 4 lay 1.4-fold (0.13 log units) below the measured number; low and high end bracket the measured number.
By their numbers in this assay, from the lowest: compounds 2, 4, 3 and 1 (each within the scatter of the next, the first and the last beyond it).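

In this assay, decyl in place of hydrogen on a saturated chain carbon, six bonds along the chain from a nitrogen on an aromatic ring, gives a 1.3-fold lower number from compound 3 to compound 4 (0.12 log units; within the scatter). This much longer addition therefore stays within the scatter, whereas the earlier ethyl addition gave a 2.1-fold higher number from compound 2 to compound 3 (0.31 log units; beyond the scatter). No measurement at hand gives a reason for this result. The compounds shown leave open whether an octyl chain, or a chain ending in an amine or a carboxylic acid, would stay as close to compound 3.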